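The source may hold more compounds than are shown below. What is called first, only, known or untested is meant among the compounds shown, and "the series" means these compounds.

Compound 1 `CCOC(=O)c1oc2ccc(NS(=O)(=O)c3ccc(Cl)cc3)cc2c1C`: 24300 nM
Compound 2 `CCOC(=O)c1oc2ccc(NS(=O)(=O)c3ccc(F)cc3)cc2c1C`: 10500 nM
Compound 3 `CCOC(=O)c1oc2ccc(N(Cc3ccccc3)S(=O)(=O)c3ccc(Br)cc3)cc2c1C`: 9460 nM

In a functional assay on HCT-116 cells (Homo sapiens) for inhibition, read by MTT assay, with a stated time of 72 h (a lower number here means a stronger inhibitor, a higher number a weaker inhibitor), compound 3 gives the lowest of the three numbers, but compound 2 lies within the scatter of it; only compound 1 is clearly higher. Compound 4 `CCOC(=O)c1oc2ccc(N(Cc3ccccc3)S(=O)(=O)c3ccc(C(F)(F)F)cc3)cc2c1C` differs from compound 3 by trifluoromethyl in place of bromo on an aromatic carbon. Within the data shown here, no measured pair makes this exact change. Among the measured compounds shown here, the one measured step, a 2.3-fold lower number from compound 1 to compound 2 (0.36 log units; beyond the scatter), swaps one halogen for another and is modest, so exchanging the halogen of compound 3 for a trifluoromethyl group is likewise expected to move the number only a little in this assay, with no firm direction. For compound 4 the expected value is 9000 nM, with a range from 3500 nM to 25000 nM. That amounts to an expected step of a 1.1-fold lower number from compound 3 to compound 4 (0.02 log units; within the scatter).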

Compound 4, half-maximal inhibitory concentration: 26700 nM
The estimate for compound 4 lay 3.0-fold (0.47 log units) below the measured number; the measured number lies above the stated range.
By their numbers in this assay, from the lowest: compounds 3 and 2 (each within the scatter of the next); then compounds 1 and 4 (each within the scatter of the next).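

In this assay, replacing 4-bromophenyl with 4-(trifluoromethyl)phenyl gives a 2.8-fold higher number from compound 3 to compound 4 (0.45 log units; beyond the scatter) and so moves the number beyond the scatter. The earlier step, a 2.3-fold lower number from compound 1 to compound 2 (0.36 log units; beyond the scatter) on swapping one halogen for another, involved only halogens; this step shows that a group other than a halogen on this aromatic carbon can also shift the number, here towards a weaker inhibitor. Nothing measured here offers a reason for this rise.

On these data alone, whether an amine, a methoxy group or a carboxylic acid on this carbon would give a lower number remains open. So does whether the same change would act alike on compounds shaped like compound 2.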